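A few compounds are considered here, and "the series" means these few. Any claim that something is new, unique, unknown or untested is made for them only; others in the source may bear on it.

Compound 1, `Cc1cc(CNC[C@@H]2CCCN3CCCC[C@H]23)c(C)n1Nc1ccnc2cc(Cl)ccc12`: in an ADME assay on K562 cells (Homo sapiens) for cytotoxicity, read by MTT assay (on this read-out lower numbers stand for stronger inhibition and higher numbers for weaker inhibition), compound 1 gives "not determined" (no result reported).
Compound 2, `CCN(CC)Cc1cc(-c2ccccc2)n(Nc2ccnc3cc(Cl)ccc23)c1C`: in this assay compound 2 gives 3620 nM.
Compound 3, `Cc1c(CNC(C)(C)C)cc(-c2ccccc2)n1Nc1ccnc2cc(Cl)ccc12`: in this assay compound 3 gives "not determined" (no result reported).

Three compounds sharing the same core were studied, but only one of them carries a number. For the measured compounds named here, compound 3 stands without a value in this assay, and compound 1 is in the same position, so the only reading to lean on is that of compound 2. That reading sits in a range where the cells are affected only at a fairly high concentration.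

Compound 4, `Cc1c(CNC[C@@H]2CCCN3CCCC[C@H]23)cc(-c2ccccc2)n1Nc1ccnc2cc(Cl)ccc12`, is the unmeasured compound. It is derived from compound 3 by a single change: a group of 11 heavy atoms (10 carbon, 1 nitrogen; 2 six-membered non-aromatic rings with 1 hetero atom each) in place of a group of 4 heavy atoms (4 carbon; no ring), on an amine nitrogen. The group that enters is the same one carried by compound 1, while the rest of compound 4 matches compound 3 and compound 2. Going by the values given here, since neither compound 3 nor compound 1 offers a number, no step can be computed, and there is nothing to say about the direction or size of the change. The measurement of compound 2 is the closest anchor available.

On that basis compound 4 is expected to give about 3500 nM in this assay, with a wide range from 800 nM to 15000 nM reflecting the missing data for its nearest relatives.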

Compound 4, half-maximal inhibitory concentration: 1680 nM
Beside the measured number, compound 4's estimate is 2.1-fold (0.32 log units) above it; the measured number falls inside the stated range.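

In this assay, for the compounds shown here, the first readable comparison in this set is a 2.2-fold lower number from compound 2 to compound 4 (0.33 log units; beyond the scatter) and it comes with the change to the two-ring group with defined stereocentres. At this place, on a saturated chain carbon bound to an aromatic carbon, that much larger group is therefore tolerated, and the cells respond at a modestly lower concentration, although compound 4 still needs a fairly high concentration to affect them. No measurement shown here gives a reason for this difference.

On these data alone, compound 1 and compound 3 carry no number, so the steps that involve them cannot be read, and how tert-butyl compares with the two-ring group on the amine nitrogen remains unknown. As far as these compounds go, with only compound 2 and compound 4 to compare, it also remains open whether the modest shift depends on both rings or on their defined stereocentres, and how a single-ring piperidine or a morpholine would behave in the same place.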